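The compounds below may be only part of what the source reports. "The series", "measured", "known", "first", "only" and "open" are said of these compounds alone.

In a functional assay on HCT-116 cells (Homo sapiens) for antiproliferative activity, read by MTT assay, with a stated time of 24 h (on this read-out lower numbers stand for stronger inhibition and higher numbers for weaker inhibition), compound 3 `COc1ccc(C(=O)/C=C/c2cccc(Cl)c2)c2c1C=CC(C)(C)O2` gives > 10000 nM, which is a limit of the assay and not a number. Compound 1 `COc1ccc(/C=C/C(=O)c2ccc(OC)c3c2OC(C)(C)C=C3)c(F)c1` gives > 10000 nM, also a limit. Compound 2 `COc1ccc(/C=C/C(=O)c2ccc(OC)c3c2OC(C)(C)C=C3)cn1` gives > 10000 nM, again a limit. The picture so far is therefore (the limit of > 10000 nM in this assay, at which 3 of the 3 values shown sit). Compound 4 `COc1ccc(C(=O)/C=C/c2cccs2)c2c1C=CC(C)(C)O2` carries thiophen-2-yl in place of 3-chlorophenyl on a double-bonded chain carbon bound to a double-bonded chain carbon. Three measured steps changed the group at this same place: a step that the two limits leave unreadable from compound 1 to compound 3, a step that the two limits leave unreadable from compound 2 to compound 3 and a step that the two limits leave unreadable from compound 1 to compound 2. None of them offers a size to carry over, so no change beyond the scatter is expected in either direction, and another limit is likely. The expected step is a step that the limit leaves unreadable from compound 3 to compound 4. The estimate for compound 4 is 12000 nM, within an expected range from 5000 nM to 30000 nM.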

Compound 4, half-maximal inhibitory concentration: > 10000 nM
Compound 4: no number, only a limit; the forecaster's own chance of this, stated with the estimate: 80%; the middle value is on the limit's open side.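

Compound 4 gives > 10000 nM, a limit and not a number. Its steps from compound 1, compound 2 and compound 3 therefore cannot be read: the limit of > 10000 nM in this assay, at which 4 of the 4 values shown sit. Going by these compounds, whether changing the group at this place alters the activity at all stays open.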